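A few compounds are considered here, and "the series" means these few. Any claim that something is new, unique, unknown or untested is made for them only; others in the source may bear on it.

Compound 2 `Cc1c(Nc2nc(N)c3c(C#N)c(N4CCC[C@H]4C)n(C)c3n2)cnn1[C@H]1CCOC1` stands at the lowest of the two numbers obtained so far in an assay on isolated protein for inhibition of Leucine-rich repeat serine/threonine-protein kinase 2 (Homo sapiens), read by TR-FRET and LanthaScreen, with stated times of 50 min and 30 min, in the presence of a further agent that is not named here; on this read-out lower numbers stand for stronger inhibition and higher numbers for weaker inhibition: compound 2 gives 23 nM, whereas compound 1 `Cc1c(Nc2nc(N)c3c(C#N)c(N4CCC[C@H]4C)n(C)c3n2)cnn1C` gives 75 nM. Among the compounds with values here, the only step that joins two measured compounds is a 3.3-fold lower number from compound 1 to compound 2 (0.51 log units; beyond the scatter), which comes from putting oxolan-3-yl in place of methyl on the aromatic nitrogen.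

Compound 3 `Cc1c(Nc2nc(N)c3c(C#N)c(N4CCC[C@H]4C)n(C)c3n2)cnn1CC1(O)COC1` changes that same aromatic nitrogen once more: (3-hydroxyoxetan-3-yl)methyl in place of oxolan-3-yl on an aromatic nitrogen. Within the data shown here, the one measured step bears on this only partly. It shows that the move from methyl to a five-membered ring on that nitrogen lowered the number, but nothing has yet been measured for a group that carries a hydrogen-bond donor and a four-membered ring at this place. With so little to go on, the number for compound 3 is expected to stay close to that of compound 2, and the expected step is a 1.5-fold higher number from compound 2 to compound 3 (0.18 log units; within the scatter), which is not beyond the scatter in either direction. Compound 3 is therefore estimated at 35 nM in this assay, with a range from 12 nM to 100 nM.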

Compound 3, half-maximal inhibitory concentration: 16 nM
Compound 3: the middle estimate sits 2.2-fold (0.34 log units) above what was measured, and the stated range covers the measured number.
By their numbers in this assay, from the lowest: compounds 3 and 2 (each within the scatter of the next); then compound 1.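

In this assay, the aromatic nitrogen takes a second, quite different group with no change beyond the scatter (a 1.4-fold lower number from compound 2 to compound 3 (0.16 log units; within the scatter)), so a four-membered ring with a hydroxyl group on a one-carbon link and a directly attached five-membered ring cannot be told apart at this place. Compared with methyl, the same group gives a step beyond the scatter (a 4.7-fold lower number from compound 1 to compound 3 (0.67 log units; beyond the scatter)), so the lower number seen with compound 2 is not tied to oxolan-3-yl alone, and compound 3 reaches the same range with no defined stereocentre in the entering group. Nothing among the available data explains these numbers.

The three compounds leave open which feature of the two larger groups goes with the lower number, the added heavy atoms, the ring oxygen or, in compound 3, the hydroxyl group. On these data alone, an oxetan-3-ylmethyl group without the hydroxyl, an all-carbon cyclobutylmethyl group, or a piperidin-4-yl amine on this nitrogen would bear on that, and whether a carboxylic acid is accepted here also remains unknown.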